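A few compounds are considered here, and "the series" means these few. Any claim that something is new, unique, unknown or untested is made for them only; others in the source may bear on it.

Measured compounds:
compound 1, `C[C@@H](NC(=O)c1ccc(C#Cc2ccccc2F)cn1)C(C)(C)O`, 29.6%
compound 2, `C[C@@H](NC(=O)c1ccc(C#Cc2ccc(F)cc2F)cn1)C(C)(C)O`, 38.2%
compound 3, `C[C@@H](NC(=O)c1ccc(C#CC2CCCC2)cn1)C(C)(C)O`, 14.8%

The three measured compounds share one core and differ only in the group on the triple-bonded carbon. In an ADME assay on HEK293 cells for agonist activity at metabotropic glutamate receptor 5 (Rattus norvegicus), read by fluorescence and calcium flux (on this read-out higher numbers stand for larger maximal responses and lower numbers for smaller maximal responses), compound 3 stands lowest of the three; its nearest neighbour is compound 1, and compound 2 lies furthest from it. The step from a fluorinated aromatic group to the saturated ring was a number 14.8 percentage points lower from compound 1 to compound 3 (beyond the scatter) and a number 23.4 percentage points lower from compound 2 to compound 3 (beyond the scatter), both modest but beyond the scatter, while a number 8.6 percentage points higher from compound 1 to compound 2 (within the scatter) adding a second fluorine stayed within the scatter.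

Compound 4, `C[C@@H](NC(=O)c1ccc(C#Cc2ccc(F)cn2)cn1)C(C)(C)O`, has not yet been measured. Its change from compound 3 is 5-fluoropyridin-2-yl in place of cyclopentyl on a triple-bonded carbon. Within the data shown here, this runs the earlier steps backwards: an aromatic ring returns to the triple-bonded carbon, now a six-membered aromatic ring with one hetero atom rather than a fluorophenyl. The two steps that bear on it, from compound 1 to compound 3 and from compound 2 to compound 3, both point to a gain in maximal response when an aromatic group sits there. Whether a ring nitrogen matches a fluorophenyl cannot be read from these three compounds, so the expectation rests on the size of those two steps alone.

Compound 4 is therefore expected to rise by a number 15.2 percentage points higher from compound 3 to compound 4 (beyond the scatter), a modest step beyond the scatter. The estimate for compound 4 in this assay is 30%, with a range from 16% to 45%.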

Compound 4, largest response reached (reported as efficacy), in percent of the reference or control that the assay uses: 13.5%
Estimate against measurement, compound 4: 16.5 percentage points above, and the stated range ends above it.
By their numbers in this assay, from the lowest: compounds 4 and 3 (each within the scatter of the next); then compounds 1 and 2 (each within the scatter of the next).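

In this assay the 5-fluoropyridin-2-yl group on the triple-bonded carbon shows no separation from cyclopentyl (a number 1.3 percentage points lower from compound 3 to compound 4 (within the scatter)), so an aromatic ring at this place does not by itself go with the larger maximal response seen for compound 1 and compound 2. Both fluorophenyl compounds stay clear of the new compound (a number 24.7 percentage points lower from compound 2 to compound 4 (beyond the scatter); a number 16.1 percentage points lower from compound 1 to compound 4 (beyond the scatter)), which shifts the contrast from aromatic against saturated to the two fluorophenyl groups against the other two groups. Compound 4 is the case that goes against the simpler aromatic reading, and it shows that exchanging one aromatic ring for another at this place can produce a step beyond the scatter.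

The data shown offer nothing that accounts for compound 4 falling level with compound 3. The compounds also leave open whether the ring nitrogen or the placement of the fluoro group separates compound 4 from the fluorophenyl compounds, a question that a plain phenyl, an unfluorinated pyridin-2-yl or a pyrimidinyl ring on the triple-bonded carbon would bear on.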